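A Rearranged Side Chain on Compound 1

The source may hold more compounds than are shown below. What is called first, only, known or untested is meant among the compounds shown, and "the series" means these compounds.

Among the compounds with values here, in a functional assay on the whole organism for inhibition, with Amphibalanus amphitrite as the target, with a stated time of 24 h (a higher number here means that more compound is needed for the effect, a lower number that less compound is needed), compound 1 (`COc1cc(C)c(O)c(C/C=C(\C)CC(=O)/C=C(/C)CCCC(C)C(=O)C(O)C=C(C)C)c1`) gives 1 ug/mL, the only actual number so far. Compound 2 (`COc1cc(C)c(O)c(C/C=C(\C)CC(=O)/C=C(\C)CCCC(C)C(=O)C(O)C=C(C)C)c1`) gives > 100 ug/mL; > 100 ug/mL (2 entries), which is a limit of the measurement and not a number. Compound 3 (`COc1cc(C)c(O)c(C/C=C(\C)CC(=O)/C=C(/C)CCCC(C)C(O)C(=O)C=C(C)C)c1`) has the same atoms as compound 1, joined differently: hydroxy((2-methylprop-1-en-1-yl)carbonyl)methyl in place of (1-hydroxy-3-methylbut-2-en-1-yl)carbonyl on a saturated chain carbon bound to two saturated chain carbons. Within the data shown here, no measured pair shows this kind of change, so the size of the step is a judgement. A moderate move towards needing more compound is expected, a 3.0-fold higher number from compound 1 to compound 3 (0.48 log units; beyond the scatter). For compound 3, the estimated value is 3 ug/mL, with an expected range from 0.5 ug/mL to 30 ug/mL.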

Compound 3, half-maximal effective concentration: > 100 ug/mL
Compound 3 ended at the assay's limit (the forecaster's own chance of this, stated with the estimate: 15%); middle value at least 33-fold (1.52 log units) away from the limit.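

Exchanging (1-hydroxy-3-methylbut-2-en-1-yl)carbonyl for hydroxy((2-methylprop-1-en-1-yl)carbonyl)methyl leaves the atoms unchanged, yet this assay records an at least 100-fold higher number from compound 1 to compound 3 (2.00 log units; beyond the scatter). The activity of compound 1 therefore depends on how these atoms are joined on this saturated chain carbon, not only on which atoms are present. Compound 3 stands at a limit and not at a number, so its step has no known upper end: the limit of > 100 ug/mL in this assay, at which 1 of the 3 values shown sits.

The compounds shown do not reveal whether the hydroxy group or the carbonyl matters more. From the compounds shown here alone, how an amine or a longer chain would fare in this place remains open.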